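Removing a Methoxy from the Fused Core

The source may hold more compounds than are shown below. What is called first, only, known or untested is meant among the compounds shown, and "the series" means these compounds.

- Compound 1 `COc1ccc2nc(-c3ccc(N/C=C\C(=O)c4ccc(OC)c([N+](=O)[O-])c4)cc3)sc2c1` gives 23600 nM in a functional assay on MIA PaCa-2 cells (Homo sapiens) for antiproliferative activity, read by sulforhodamine B assay, with a stated time of 48 h; a lower number here means a stronger inhibitor, a higher number a weaker inhibitor.
- Compound 2 `COc1ccc2nc(-c3ccc(N/C=C\C(=O)c4cc(OC)c(OC)c([N+](=O)[O-])c4)cc3)sc2c1` gives 25600 nM in this assay.
- Compound 3 `COc1cc(C(=O)/C=C\Nc2ccc(-c3nc4cc(OC)c(OC)c(OC)c4s3)cc2)cc([N+](=O)[O-])c1OC` gives 15800 nM in this assay.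

Compound 1 and compound 2 share a core; compound 1 differs from compound 2 by hydrogen in place of methoxy on an aromatic carbon, and that change made a step of a 1.1-fold lower number from compound 2 to compound 1 (0.04 log units; within the scatter). Compound 3 carries a different core, and the difference between the two cores is not broken down here.

Compound 4 `COc1cc(OC)c2sc(-c3ccc(N/C=C\C(=O)c4cc(OC)c(OC)c([N+](=O)[O-])c4)cc3)nc2c1` has not yet been measured. It differs from compound 3 by hydrogen in place of methoxy on an aromatic carbon. This is the same kind of change as from compound 2 to compound 1, but the surroundings differ: in compound 4 the hydrogen enters on a six-membered aromatic ring of carbon only that is part of a fused or bridged system of two rings, ortho to two methoxy groups, meta to a fused ring and para to a fused ring, whereas in compound 1 it enters ortho to a methoxy group, meta to a large group and meta to a nitro group.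

Because the earlier step of a 1.1-fold lower number from compound 2 to compound 1 (0.04 log units; within the scatter) stayed within the scatter, a similarly small step is expected here: a 1.1-fold higher number from compound 3 to compound 4 (0.03 log units; within the scatter). Compound 4 is therefore estimated at 17000 nM, with a likely range from 7000 nM to 40000 nM.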

Compound 4, half-maximal inhibitory concentration: 12700 nM
Compound 4: middle estimate off by 1.3-fold (0.13 log units), on the high side; low and high end bracket the measured number.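

In this assay, putting hydrogen in place of methoxy on the ring that is part of a fused system gave a 1.2-fold lower number from compound 3 to compound 4 (0.09 log units; within the scatter). Set beside the same swap on the other core, the change carries over between these two cores with no difference that can be told apart from the scatter: the same change on two cores in this assay, a 1.1-fold lower number (0.04 log units; within the scatter) from compound 2 to compound 1 and a 1.2-fold lower number (0.09 log units; within the scatter) from compound 3 to compound 4, 1.1-fold (0.06 log units) apart, within the scatter of two such steps This shows only that, in these two pairs, losing a methoxy left the number within the scatter, at two different places in the molecule; it does not show that the result would hold on a third core, or that methoxy is unimportant at every position.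

The compounds shown leave open what a group other than methoxy or hydrogen would do at these places, such as a hydroxyl, a chlorine atom, an amine or a longer alkoxy chain. They also leave open whether the nitro group on the other ring could give way to a nitrile or a carboxylic acid.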